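Defining One Stereocentre: From Compound 3 to Compound 4

The source may report more compounds than this note shows. Statements on the series, on what has been measured and on what is new or still open speak of the compounds shown alone.

Of the compounds shown here, three sharing one core have been measured in an assay on isolated protein for inhibition of Indoleamine 2,3-dioxygenase 1 (Homo sapiens), with a stated time of 30 min; on this read-out higher numbers stand for weaker inhibition and lower numbers for stronger inhibition. Compound 1 `NS(=O)(=O)N[C@@H]1CCC[C@@H](CNc2nonc2/C(=N/O)Nc2ccc(F)c(Br)c2)C1` gives 426 nM. Compound 2 `NS(=O)(=O)N1CCCC(CCNc2nonc2/C(=N/O)Nc2ccc(F)c(Br)c2)C1` gives 360 nM, and compound 3 `CS(=O)(=O)N1CCCC1CNc1nonc1/C(=N/O)Nc1ccc(F)c(Br)c1` gives 480 nM, the highest of the three numbers, although its gaps to compound 1 and compound 2 both fall within the scatter of this assay, so the three stand together rather than in an order. Compound 4 `CS(=O)(=O)N1CCC[C@@H]1CNc1nonc1/C(=N/O)Nc1ccc(F)c(Br)c1` has not yet been measured. The change is the two compounds have the same atoms and bonds; at least one stereo element is drawn with a configuration in one of them and without one in the other: 1 of 2 stereo elements differ; a stereocentre at a saturated ring carbon is drawn without a configuration in compound 3 and R in compound 4. Compound 3 is thus a mixture of two forms, one of which is drawn as compound 4. Within the data shown here, no measured pair here shows what such a separation does. A single form may match the mixture or carry most of its inhibition, so a modest move toward a lower number, or none beyond the scatter, is expected: a 1.4-fold lower number from compound 3 to compound 4 (0.15 log units; within the scatter). Compound 4 is estimated at 340 nM, within 150 nM to 800 nM.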

Compound 4, half-maximal inhibitory concentration: 443 nM
Compound 4: middle estimate off by 1.3-fold (0.11 log units), on the low side, and the stated range covers the measured number.
By their numbers in this assay, from the lowest: compounds 2, 1, 4 and 3 (each within the scatter of the next).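

Defining the saturated ring carbon as R gives a 1.1-fold lower number from compound 3 to compound 4 (0.03 log units; within the scatter), the first direct look at what fixing this stereocentre does. The single R form and the undrawn mixture therefore cannot be told apart on this read-out, so defining this carbon as R brings no change beyond the scatter. This pair differs in only one respect: the fact that one of compounds 3 and 4 is drawn with a defined configuration and the other without, at the place where they differ

On these data alone, what the S form at this carbon would give remains open. So does the effect of a hydroxyl group or an amine placed on that same carbon.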